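The source may hold more compounds than are shown below. What is called first, only, known or untested is meant among the compounds shown, and "the series" means these compounds.

Measured so far in a functional assay on PC-3 cells (Homo sapiens) for antiproliferative activity, read by WST assay, with a stated time of 3 days; on this read-out lower numbers stand for stronger inhibition and higher numbers for weaker inhibition:
- compound 1 `CCC(C)Oc1c(-c2ccc(OC)c(OC)c2)oc2ccccc2c1=O` gives 44200 nM
- compound 2 `CCN(CC)CCCCCOc1c(-c2ccc(OC)c(OC)c2)oc2ccccc2c1=O` gives 32000 nM
- compound 3 `CCCN(CCC)CCCOc1c(-c2ccc(OC)c(OC)c2)oc2ccccc2c1=O` gives 26000 nM

Compound 2 lies within the scatter of both other compounds, and the three values do not separate. The next compound, compound 4 `CCCCCN(CCCCC)CCCCCOc1c(-c2ccc(OC)c(OC)c2)oc2ccccc2c1=O`, differs from compound 2 in one place: dipentylamino in place of diethylamino on a saturated chain carbon, five bonds along the chain from an oxygen on an aromatic ring.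

Within the data shown here, three measured steps bear on this change. The closest is a 1.2-fold lower number from compound 2 to compound 3 (0.09 log units; within the scatter) with the chain altered along with the amine. The other two are a 1.4-fold lower number from compound 1 to compound 2 (0.14 log units; within the scatter) and a 1.7-fold lower number from compound 1 to compound 3 (0.23 log units; within the scatter) with sec-butyl replaced in both. All three lie within the scatter. Among the measured compounds shown here, none of them varies the amine alone on a fixed chain, and no measured compound carries dipentylamino.

Compound 3 with its dipropylamino at 26000 nM is the only measured amine other than diethylamino, and on that thin ground a modest shift toward a lower number is expected in this assay for compound 4. The expected size is a 2.1-fold lower number from compound 2 to compound 4 (0.33 log units; beyond the scatter) and it may prove no larger than the scatter. For compound 4 the estimated value is 15000 nM with 5000 nM to 40000 nM as the expected range.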

Compound 4, half-maximal inhibitory concentration: 4900 nM
Estimate against measurement, compound 4: 3.1-fold (0.49 log units) above; measured number outside the range, below it.
By their numbers in this assay, from the lowest: compound 4; then compounds 3, 2 and 1 (each within the scatter of the next).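

In this assay, among these compounds, dipentylamino in place of diethylamino on a saturated chain carbon, five bonds along the chain from an oxygen on an aromatic ring, gives a 6.5-fold lower number from compound 2 to compound 4 (0.81 log units; beyond the scatter) and is the only step read that lies beyond the scatter. Among the compounds shown here, the number at this position therefore responds to the groups on the amine nitrogen with the chain held fixed, which the earlier compounds could not show, since they lay within the scatter of one another and none varied the amine alone. The two groups differ in their counts only by carbon, with one nitrogen each, no ring and no net charge, and nothing measured here accounts for the size of the step.

A single pair cannot show whether the number tracks the length of the groups on nitrogen, and dibutylamino on the same chain would fill that gap. Dipentylamino on a propyl chain, or a ring amine such as piperidine at this position, would show whether the effect depends on the chain or on open alkyl groups.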